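Trimming the Sulfonamide: What to Expect for Compound 3

The source may hold more compounds than are shown below. What is called first, only, known or untested is meant among the compounds shown, and "the series" means these compounds.

Compound 1 `Cc1ccc(S(=O)(=O)N(C)CC(C)C)cc1C#Cc1cc(Cl)ccc1OCC(=O)O` has been measured in an in vitro ADME assay on microsomes from liver (Homo sapiens) for metabolic stability, read by LC-MS, tested at 1 uM (on this read-out higher numbers stand for fast clearance and lower numbers for slow clearance), where compound 1 gives 79 mL.min-1.g-1. That is the highest of the two numbers recorded. Compound 2 `CCCS(=O)(=O)c1ccc(F)c(C#Cc2cc(Cl)ccc2OCC(=O)O)c1` gives 12 mL.min-1.g-1 in this assay, a lower number, and the gap between the two lies beyond the scatter. Among the measured compounds shown here, no measured pair differs in a single place, so no isolated step can be read from what has been measured.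

Compound 3 `Cc1ccc(S(C)(=O)=O)cc1C#Cc1cc(Cl)ccc1OCC(=O)O` is still to be measured. It differs from compound 1 by the change (methyl in place of isobutyl(methyl)amino on a sulfonyl sulfur), on a sulfonyl sulfur whose other neighbour is an aromatic carbon. Without a measured single-point step, the size of the move can only be estimated. The step of a 3.2-fold lower number from compound 1 to compound 3 (0.50 log units; beyond the scatter) is expected to lower the number, by more than the scatter. The value of compound 3 is estimated at 25 mL.min-1.g-1, within a range from 9 mL.min-1.g-1 to 60 mL.min-1.g-1.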

Compound 3, intrinsic clearance in microsomes: 14 mL.min-1.g-1
Compound 3: the middle estimate sits 1.8-fold (0.25 log units) above what was measured; the measured number falls inside the stated range.
By their numbers in this assay, from the lowest: compounds 2 and 3 (each within the scatter of the next); then compound 1.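

Among the compounds shown here, this gives the first single-place step in this assay: methyl in place of isobutyl(methyl)amino on a sulfonyl sulfur gives a 5.6-fold lower number from compound 1 to compound 3 (0.75 log units; beyond the scatter). It shows that the group on this sulfur, whose other neighbour is an aromatic carbon, bears on the read-out, and that the change from six heavy atoms to one moves the number beyond the scatter while the rest of compound 1 stays the same. Nothing at hand accounts for the size or direction of this step.

The compounds shown cannot separate the part played by the nitrogen from that of the isobutyl chain, as both leave together. Going by these compounds, a dimethylamino or an ethyl group on the same sulfur would divide the step, and how either reads remains open.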